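Cyclopropyl-Alkynyl Uridine: Expected Tolerance in Vero Cells

The source may report more compounds than this note shows. Statements on the series, on what has been measured and on what is new or still open speak of the compounds shown alone.

Measured compounds:
- compound 1, `CCCCC#Cc1cn([C@@H]2O[C@H](CO)[C@@H](O)[C@H]2O)c(=O)[nH]c1=O`: 103000 nM
- compound 2, `O=c1[nH]c(=O)n([C@@H]2O[C@H](CO)[C@@H](O)[C@H]2O)cc1C#CC(O)c1ccccc1`: 65400 nM
- compound 3, `O=c1[nH]cc(C#CC(O)c2ccccc2)c(=O)[nH]1`: 242000 nM

These values come from an ADME assay on Vero cells (Chlorocebus sabaeus) for cytotoxicity, read by MTT assay; a higher number here means that more compound is tolerated, a lower number that less compound is tolerated. Among the three, compound 2 gives the lowest number, though the gap to compound 1 is within the scatter, and only compound 3 sits clearly apart, a 3.7-fold higher number from compound 2 to compound 3 (0.57 log units; beyond the scatter).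

Compound 4, `O=c1[nH]c(=O)n([C@@H]2O[C@H](CO)[C@@H](O)[C@H]2O)cc1C#CC1CC1`, differs from compound 2 in one place: cyclopropyl in place of hydroxy(phenyl)methyl on a triple-bonded carbon. The step that bears on this is the swap of the same group for a plain chain, a 1.6-fold lower number from compound 1 to compound 2 (0.20 log units; within the scatter), which stayed within the scatter. A small ring entering in place of the hydroxy(phenyl)methyl group is therefore expected to move this assay little, if at all; the expected step is a 1.4-fold higher number from compound 2 to compound 4 (0.14 log units; within the scatter). The estimate for compound 4 is 90000 nM, expected to fall between 45000 nM and 180000 nM.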

Compound 4, half-maximal cytotoxic concentration: 133000 nM
For compound 4 the middle estimate is 1.5-fold (0.17 log units) below the measured one; the measured number falls inside the stated range.
By their numbers in this assay, from the lowest: compounds 2, 1, 4 and 3 (each within the scatter of the next, the first and the last beyond it).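

Placing cyclopropyl on the triple-bonded carbon gives a 2.0-fold higher number from compound 2 to compound 4 (0.31 log units; beyond the scatter), the first change at this position shown to lie beyond the scatter, though the step is modest. Cyclopropyl and butyl cannot be told apart here, with a 1.3-fold higher number from compound 1 to compound 4 (0.11 log units; within the scatter), so this small ring and the plain chain are tolerated alike. Nothing available explains these results.

From the compounds shown here alone, how an amine or a carboxylic acid on the triple-bonded carbon would fare remains open. So does whether replacing 3,4-dihydroxy-5-(hydroxymethyl)oxolan-2-yl with hydrogen would raise the number for compound 4 as it does for compound 2.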